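Butyl in place of 4-bromophenyl on a sulfur

The source may report more compounds than this note shows. Statements on the series, on what has been measured and on what is new or still open speak of the compounds shown alone.

The measured compounds in a functional assay on MGC-803 cells (Homo sapiens) for cytotoxicity, read by MTT assay, with a stated time of 48 h (a higher number here means a weaker inhibitor, a lower number a stronger inhibitor), are these

Compound 1 `O=C(CSc1ccccc1)N1N=C(c2cc3ccccc3oc2=O)C[C@@H]1c1ccccc1` gives 22800 nM
Compound 2 `O=C(CSc1ccc(Br)cc1)N1N=C(c2cc3ccccc3oc2=O)C[C@@H]1c1ccccc1C(F)(F)F` gives 21300 nM
Compound 3 `O=C(CSc1ccc(Br)cc1)N1N=C(c2cc3ccccc3oc2=O)C[C@@H]1c1ccccc1` gives 16800 nM

On these numbers compound 3 stands level with the other two, as all three values lie within the scatter of one another. The unmeasured compound 4 `CCCCSCC(=O)N1N=C(c2cc3ccccc3oc2=O)C[C@@H]1c1ccccc1` departs from compound 3 on the group carried by the sulfur, with the difference butyl in place of 4-bromophenyl on a sulfur. Among the measured compounds shown here, two measured steps bear on this change, and only indirectly. Bromo in place of hydrogen on an aromatic carbon gave a 1.4-fold lower number from compound 1 to compound 3 (0.13 log units; within the scatter) and hydrogen in place of trifluoromethyl on an aromatic carbon gave a 1.3-fold lower number from compound 2 to compound 3 (0.10 log units; within the scatter) and neither step goes beyond the scatter. The first of these alters the aromatic group on the sulfur but keeps it in place. For the measured compounds named here, no measured compound carries a chain there, so the data do not show what removing that aromatic group does. The expected size of the change is therefore modest but uncertain, with no shift beyond the scatter anticipated. The expected step is a 1.3-fold higher number from compound 3 to compound 4 (0.12 log units; within the scatter) and it rests on little evidence. For compound 4 the estimate is 22000 nM with 9000 nM to 55000 nM as the expected range.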

Compound 4, half-maximal inhibitory concentration: 12900 nM
Compound 4: the middle estimate sits 1.7-fold (0.23 log units) above what was measured, within the range that was stated.
By their numbers in this assay, from the lowest: compounds 4, 3, 2 and 1 (each within the scatter of the next).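

In this assay, the sulfur substituent can lose its aromatic ring altogether without leaving the scatter: butyl in place of 4-bromophenyl gives a 1.3-fold lower number from compound 3 to compound 4 (0.11 log units; within the scatter), and butyl in place of phenyl gives a 1.8-fold lower number from compound 1 to compound 4 (0.25 log units; within the scatter). The earlier compounds shown here had varied only a substituent on the aromatic group at this sulfur, whereas these two steps show that a saturated chain with no ring can stand there and that the aromatic group is not required for a value in this range. Nothing available explains this tolerance, and no further measurement bears on it.

The compounds shown leave open whether any group on this sulfur can move the number beyond the scatter, for example a methyl, a longer chain such as octyl, or a chain ending in an amine or a carboxylic acid. They also leave open whether butyl gives a similar result when the shared core carries trifluoromethyl on its phenyl ring, as compound 2 does, since the butyl group is seen here only with the unsubstituted phenyl ring.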